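A few compounds are considered here, and "the series" means these few. Any claim that something is new, unique, unknown or untested is made for them only; others in the source may bear on it.

Three compounds share one core and were tested in a functional assay on NCI-H1581 cells (Homo sapiens) for inhibition, read by MTT assay, with a stated time of 48 h, tested at 10 uM; a lower number here means less inhibition, a higher number more inhibition at the concentration tested (going by the name of the read-out). Compound 1 `COc1ccc(Br)cc1Nc1cc(NC(=O)Nc2c(Cl)cccc2Cl)ncn1` gives 53.3%. Compound 3 `Cc1ccc(Nc2cc(NC(=O)Nc3c(Cl)cccc3Cl)ncn2)cc1C` gives 73.3%, and the step of a number 20 percentage points higher from compound 1 to compound 3 (beyond the scatter) shows a change on the nitrogen on the aromatic ring. Compound 2 `COc1cc(NC(=O)Nc2cc(Nc3cc(Br)ccc3OC)ncn2)cc(OC)c1` gives 23.1%, the lowest of the three values, and the step of a number 30.2 percentage points lower from compound 1 to compound 2 (beyond the scatter) shows a change on the amide-type nitrogen.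

Compound 4 `COc1cc(NC(=O)Nc2cc(Nc3ccc(OC)c(I)c3)ncn2)cc(OC)c1` has not yet been measured. It differs from compound 2 in one place: 3-iodo-4-methoxyphenyl in place of 5-bromo-2-methoxyphenyl on a nitrogen on an aromatic ring. Within the data shown here, the only measured step at that nitrogen is a number 20 percentage points higher from compound 1 to compound 3 (beyond the scatter), where a different group entered; no step shows an iodine for a bromine or the moved methoxy. Because that step a number 20 percentage points higher from compound 1 to compound 3 (beyond the scatter) was modest, a modest rise is expected for compound 4, with wide uncertainty, giving an estimated step of a number 11.9 percentage points higher from compound 2 to compound 4 (beyond the scatter). Compound 4 is estimated at 35%, within a range from 15% to 58%.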

Compound 4, a percentage reported as inhibition, at one concentration (the size of the read-out at that concentration, not a potency): 43%
The estimate for compound 4 lay 8 percentage points below the measured number; measured number inside the range.
By their numbers in this assay, from the lowest: compound 2; then compound 4; then compound 1; then compound 3.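

In this assay, among these compounds, the step of a number 19.9 percentage points higher from compound 2 to compound 4 (beyond the scatter) shows that this nitrogen's aromatic group can still change the number when 3,5-dimethoxyphenyl sits on the amide-type nitrogen; the only earlier step at this position, a number 20 percentage points higher from compound 1 to compound 3 (beyond the scatter), had 2,6-dichlorophenyl there instead. This new change replaces bromine with iodine and shifts the methoxy group in a single step, so it cannot show which of the two alterations accounts for the rise. No measured evidence is available to explain the rise.

Going by these compounds, it remains open whether 3-iodo-4-methoxyphenyl would also raise the number when paired with 2,6-dichlorophenyl on the amide-type nitrogen. How an amine or a carboxylic acid on this aromatic ring would behave is also unknown.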